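Chloro for Methyl at a Cytotoxicity Limit

The compounds below may be only part of what the source reports. "The series", "measured", "known", "first", "only" and "open" are said of these compounds alone.

Three compounds of one shared core have been run in an ADME assay on MDBK cells (Bos taurus) for cytotoxicity; a lower number here means that less compound is tolerated, a higher number that more compound is tolerated. Compound 1 `Fc1cccc(F)c1Cn1ccc2nc(-c3c(F)cccc3F)nc-2c1` gives > 100000 nM, which is a limit of the assay. Compound 2 `Fc1cccc(F)c1-c1nc2ccn(Cc3ccccc3)cc-2n1` gives > 100000 nM, again a limit. The step that the two limits leave unreadable from compound 1 to compound 2 therefore cannot be read. Compound 3 `Cc1cccc(Cn2ccc3nc(-c4ccccc4)nc-3c2)c1` gives > 100000 nM, likewise a limit, so compound 3 sits with the other two at the limit of > 100000 nM in this assay, at which 3 of the 3 values shown sit. Compound 4 `Clc1cccc(Cn2ccc3nc(-c4ccccc4)nc-3c2)c1` is not yet measured; its change from compound 3 is chloro in place of methyl on an aromatic carbon. Among the measured compounds shown here, no measured step touches this change, and the one step recorded is of unreadable size, so no shift beyond the scatter is expected in either direction. Compound 4 is therefore expected to give 100000 nM, between 40000 nM and 300000 nM, an expected step of a number no higher from compound 3 to compound 4 (the limit leaves the size open), most likely reported once more as a limit.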

Compound 4, half-maximal cytotoxic concentration: > 100000 nM
Compound 4: a limit, no number; the forecaster's own chance of this, stated with the estimate: 85%; the middle value lies on the limit itself.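

Compound 4 gives > 100000 nM, which is a limit, so the step from compound 3 to compound 4 cannot be read. The compounds shown leave open whether any of these changes shifts the result in this assay, and all of them rest at one limit: the limit of > 100000 nM in this assay, at which 4 of the 4 values shown sit.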